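The compounds below may be only part of what the source reports. "The series", "measured", "known", "first", "only" and "open" are said of these compounds alone.

Within the data shown here, compound 2 `COc1ccc(-c2cc3ccccc3nc2/C=C/C(=O)c2cccs2)cc1` gives 5440 nM in a functional assay on NCI-H460 cells (Homo sapiens) for antiproliferative activity, read by XTT assay, with a stated time of 72 h (on this read-out lower numbers stand for stronger inhibition and higher numbers for weaker inhibition), the lower of the two numbers so far; the other belongs to compound 1 `COc1ccc(-c2cc3ccccc3nc2/C=C/C(=O)c2ccco2)cc1`, which gives 6430 nM in this assay, and the step of a 1.2-fold lower number from compound 1 to compound 2 (0.07 log units; within the scatter) separates them. Compound 3 `COc1ccc(-c2cc3ccccc3nc2/C=C/C(=O)c2cnc(N)nc2C)cc1` differs from compound 2 by 2-amino-4-methylpyrimidin-5-yl in place of thiophen-2-yl on a carbonyl carbon. Among the measured compounds shown here, the only measured step swaps one five-membered ring for another on the same carbonyl carbon and barely moves the number; no measured step involves a six-membered ring with two hetero atoms, a hydrogen-bond donor or three acceptors at that position, so the data give no direction for this larger change. On that basis no step beyond the scatter is expected, with a wide margin on either side. For compound 3 the expected value in this assay is 5000 nM, between 1500 nM and 17000 nM, which means a step of a 1.1-fold lower number from compound 2 to compound 3 (0.04 log units; within the scatter).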

Compound 3, half-maximal inhibitory concentration: > 10000 nM
Compound 3: no number, only a limit; the forecaster's own chance of this, stated with the estimate: 10%; middle value at least 2.0-fold (0.30 log units) away from the limit.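

In this assay compound 3 gives > 10000 nM, which is a limit of the assay and not a number: the limit of > 10000 nM in this assay, at which 1 of the 3 values shown sits. The change to the larger ring reads as an at least 1.8-fold higher number from compound 2 to compound 3 (0.26 log units; that floor lies within the scatter), and as an at least 1.5-fold higher number from compound 1 to compound 3 (0.19 log units; that floor lies within the scatter). Among these compounds, this is the first six-membered ring with hetero atoms at this carbonyl carbon, and it brings no lower number than either five-membered ring, although the true size of both steps cannot be read from a limit.

The compounds shown leave open which part of 2-amino-4-methylpyrimidin-5-yl governs this result, since its amine, its methyl and its ring nitrogens all enter together. Also open, on these data alone, is how a plain phenyl ring or a pyridin-3-yl ring on the same carbonyl carbon would read in this assay.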